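The source may hold more compounds than are shown below. What is called first, only, known or untested is meant among the compounds shown, and "the series" means these compounds.

Compound 1 `COc1ccc(C(=O)c2cc(OC)c(OC)c(OC)c2)cc1NC(=O)/C=C/c1cc(OC)c(OC)c(OC)c1` gives 1500 nM in this assay.
Compound 2 `COc1ccc(C(=O)c2cc(OC)c(OC)c(OC)c2)cc1NC(=O)/C=C/c1ccc(F)cc1` gives 60 nM.

In a functional assay on HeLa cells (Homo sapiens) for cytotoxicity, read by MTT assay, with a stated time of 72 h (on this read-out lower numbers stand for stronger inhibition and higher numbers for weaker inhibition), compound 2 stands at the lowest of the two numbers, while compound 1 gives 1500 nM. Compound 3 `COc1cc(/C=C/C(=O)Nc2cc(C(=O)c3cc(OC)c(OC)c(OC)c3)ccc2OC)ccc1F` differs from compound 2 by methoxy in place of hydrogen on an aromatic carbon. For the measured compounds named here, the one measured step that bears on this, a 25-fold lower number from compound 1 to compound 2 (1.40 log units; beyond the scatter), replaced the whole 3,4,5-trimethoxyphenyl ring with 4-fluorophenyl. Putting one methoxy back moves compound 3 part of the way toward compound 1, so a modest rise in the number is expected, a 2.5-fold higher number from compound 2 to compound 3 (0.40 log units; beyond the scatter). Compound 3 is therefore estimated at 150 nM, in a range from 50 nM to 500 nM.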

Compound 3, half-maximal inhibitory concentration: 13600 nM
Estimate against measurement, compound 3: 91-fold (1.96 log units) below, outside the stated range (above it).
By their numbers in this assay, from the lowest: compound 2; then compound 1; then compound 3.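

In this assay, adding one methoxy ortho to the fluoro group gives a 230-fold higher number from compound 2 to compound 3 (2.36 log units; beyond the scatter), so this single position on the ring can matter greatly. The 4-fluoro-3-methoxyphenyl ring also falls short of the 3,4,5-trimethoxyphenyl ring, with a 9.1-fold higher number from compound 1 to compound 3 (0.96 log units; beyond the scatter), so the numbers do not simply rise with each methoxy added to this ring. Nothing available explains this loss. Going by these compounds, it remains open whether the loss is specific to methoxy, or whether a hydroxyl or a chloro group at this position would give a similarly high number.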